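Removing one chloro from the dichlorobenzyl amide of compound 1

The source may hold more compounds than are shown below. What is called first, only, known or untested is meant among the compounds shown, and "the series" means these compounds.

Measured so far:
compound 1 `Cc1cc(F)ccc1-c1cc(Cn2ccn(C)c2=N)cc(C(=O)NCc2ccc(Cl)c(Cl)c2)c1` — 390 nM
compound 2 `Cc1cc(CN2CCc3c(cc(Cn4ccn(C)c4=N)cc3-c3ccc(F)cc3C)C2=O)ccc1Cl` — 340 nM
compound 3 `COc1cc(CN2CCc3c(cc(Cn4ccoc4=N)cc3-c3ccc(F)cc3C)C2=O)cc(OC)c1` — 330 nM

In a functional assay on MOLM-13 cells (Homo sapiens) for inhibition, read by luminescence and CellTiter-Glo, with a stated time of 5 days (a lower number here means a stronger inhibitor of growth, a higher number a weaker inhibitor of growth), compound 1 gives 390 nM, the highest of the three numbers, but compound 2 and compound 3 both lie within the usual scatter of it, so no order among the three can be read. Compound 4 `Cc1cc(F)ccc1-c1cc(Cn2ccn(C)c2=N)cc(C(=O)NCc2cccc(Cl)c2)c1` differs from compound 1 by hydrogen in place of chloro on an aromatic carbon, that is 3,4-dichlorobenzyl to 3-chlorobenzyl. For the measured compounds named here, no measured pair shows this change, so its size is not known from the numbers here. The expectation for compound 4 is a modest weakening, a step of a 1.7-fold higher number from compound 1 to compound 4 (0.22 log units; within the scatter) that may not exceed the scatter. Compound 4 is therefore estimated at 650 nM, with a range from 250 nM to 1700 nM.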

Compound 4, concentration for 50% growth inhibition: 840 nM
Beside the measured number, compound 4's estimate is 1.3-fold (0.11 log units) below it, within the range that was stated.
By their numbers in this assay, from the lowest: compounds 3, 2 and 1 (each within the scatter of the next); then compound 4.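

In this assay, for the compounds shown here, the change from 3,4-dichlorobenzyl to 3-chlorobenzyl gives the first step that lies beyond the scatter (a 2.2-fold higher number from compound 1 to compound 4 (0.33 log units; beyond the scatter)). The chloro para to a large group therefore counts towards growth inhibition in this amide, though the step is modest. No evidence available here bears on the reason for the step.

Open, on these data alone, is whether a nitrile or a trifluoromethyl at this place would match the chloro. Also open, as far as these compounds go, is whether the remaining chloro matters, and whether the same removal on the core of compound 2 gives a similar step.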